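From Isopropyl to 4-Fluorophenyl on an Aromatic Nitrogen

The source may report more compounds than this note shows. Statements on the series, on what has been measured and on what is new or still open speak of the compounds shown alone.

In a functional assay on MDA-MB-468 cells (Homo sapiens) for antiproliferative activity, read by MTT assay, with a stated time of 72 h (a higher number here means a weaker inhibitor, a lower number a stronger inhibitor), compound 1 `COc1cc(-c2nccn2C(C)C)cc(OC)c1OC` gives > 100000 nM, which is a limit of the assay and not a number. Compound 2 `COc1cc(-c2nccn2-c2ccc3sccc3c2)cc(OC)c1OC`, which carries an aromatic group on the same nitrogen, gives 400 nM. Compound 3 `COc1cc(-c2nccn2-c2ccc(F)cc2)cc(OC)c1OC` has 4-fluorophenyl in place of isopropyl on an aromatic nitrogen. Because compound 2 reaches 400 nM with an aromatic group there, a gain in potency well beyond the scatter is expected in this assay. The expected step is an at least 40-fold lower number from compound 1 to compound 3 (1.60 log units; beyond the scatter). For compound 3, the estimated value is 2500 nM, with an expected range of 300 nM to 20000 nM.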

Compound 3, half-maximal inhibitory concentration: 62200 nM
Compound 3: middle estimate off by 25-fold (1.40 log units), on the low side, outside the stated range (above it).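

Compound 3 gives 62200 nM in this assay and compound 2 gives 400 nM there, so an aromatic ring on this nitrogen does not by itself bring the value of compound 2. Putting 4-fluorophenyl in place of isopropyl gives an at least 1.6-fold lower number from compound 1 to compound 3 (0.20 log units; that floor lies within the scatter) and so shows no certain gain. This step remains only a floor because compound 1 stands at a limit and not at a number: the limit of > 100000 nM in this assay, at which 1 of the 3 values shown sits.

From the compounds shown here alone, the true size of the step remains open. So does how a benzyl group or an aminoethyl chain on this nitrogen would read in this assay.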